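Extending the side chain from compound 2 to compound 3

The compounds below may be only part of what the source reports. "The series", "measured", "known", "first", "only" and "open" are said of these compounds alone.

Compound 1 (`CCC(CCO)n1cnc2c(Cl)ncnc21`) gives > 50000 nM in a functional assay on HCT-116 cells (Homo sapiens) for antiproliferative activity, read by MTT assay, with a stated time of 48 h (on this read-out higher numbers stand for weaker inhibition and lower numbers for stronger inhibition), as a limit of the assay and not a number.

Among the measured compounds shown here, compound 2 (`CCCCCCCCCC(CCO)n1cnc2c(Cl)ncnc21`) gives 890 nM in this assay and so holds the only actual number so far. The change separating the two is heptyl in place of hydrogen on a saturated chain carbon, three bonds along the chain from an aromatic nitrogen. It comes with an at least 56-fold lower number from compound 1 to compound 2 (1.74 log units; beyond the scatter) as a large step beyond the scatter.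

Compound 3 (`CCCCCCCCCCC(CCO)n1cnc2c(Cl)ncnc21`) differs from compound 2 by methyl in place of hydrogen on a saturated chain carbon, ten or more bonds along the chain from an aromatic nitrogen and is still unmeasured. For the measured compounds named here, the only measured step that bears on this change is an at least 56-fold lower number from compound 1 to compound 2 (1.74 log units; beyond the scatter) and it involved heptyl, a far larger addition than methyl. A single step, with a limit at one end, does not show whether the direction holds further along the chain.

The expected step is a 1.4-fold lower number from compound 2 to compound 3 (0.14 log units; within the scatter) in this assay and it is expected to be small, towards stronger inhibition, and probably within the scatter.

In this assay the estimate for compound 3 is 650 nM with an expected range from 280 nM to 1500 nM.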

Compound 3, half-maximal inhibitory concentration: 4930 nM
Compound 3: the middle estimate sits 7.6-fold (0.88 log units) below what was measured; the whole stated range lies below it.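

Methyl in place of hydrogen on a saturated chain carbon gives in this assay a 5.5-fold higher number from compound 2 to compound 3 (0.74 log units; beyond the scatter), so lengthening the chain does not keep moving the number in the direction of the first measured step. The octyl chain still retains a clear advantage over the short chain of the parent, with an at least 10-fold lower number from compound 1 to compound 3 (1.00 log units; beyond the scatter), and compound 2 now holds the lowest number of the three, with steps beyond the scatter to both others. The size of that advantage has an open end, since the comparison with compound 1 rests on a limit of the assay and not a number: the limit of > 50000 nM in this assay, at which 1 of the 3 values shown sits.

On these data alone, with only these chains in view, it remains open whether compound 2 marks a true optimum in chain length or one point on a more irregular profile, and how the number behaves for intermediate chains such as butyl or pentyl. Also open, as far as these compounds go, is whether a longer chain continues the rise seen with compound 3, and whether an amine or a carboxylic acid at the chain end would change the picture.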